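This account rests on a few compounds, and the source may have more. Where it says the series, first, only, none or still open, it means among the compounds named here.

In an ADME assay on microsomes from liver (Homo sapiens) for metabolic stability, read by LC-MS, using NADPH, with a stated time of 30 min, tested at 1 uM (on this read-out higher numbers stand for fast clearance and lower numbers for slow clearance), compound 1 `COc1cc2c(cn1)Oc1ccc(NC(=O)c3ccc(Cl)cn3)cc1[C@@]21COC(N)=N1` gives < 14 mL.min-1.g-1, which is a limit of the assay and not a number. Compound 1 therefore sits at the limit of < 14 mL.min-1.g-1 in this assay, at which 1 of the 3 values shown sits. Two further compounds do give numbers: compound 2 `CC#Cc1cncc(-c2ccc3c(c2)[C@@]2(COC(N)=N2)c2cc(C4=CCCOC4)ncc2O3)c1` gives 76 mL.min-1.g-1, and compound 3 `CC1(C#Cc2cncc(-c3ccc4c(c3)[C@@]3(COC(N)=N3)c3cc(C5=CCOCC5)ncc3O4)c2)COC1` gives 420 mL.min-1.g-1.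

Compound 4 `NC1=N[C@@]2(CO1)c1cc(NC(=O)c3ccc(Cl)cn3)ccc1Oc1cnc(C3CCOCC3)cc12` keeps the rest of compound 1 and changes one group on the shared core: oxan-4-yl in place of methoxy on an aromatic carbon. In words, oxan-4-yl stands in place of methoxy on an aromatic carbon. Going by the values given here, no measured pair here shows this swap on its own, so its effect in this assay can only be estimated. Clearance is expected to rise modestly, but not to approach compound 2 at 76 mL.min-1.g-1. An upward move of moderate size is the estimate, an at least 1.7-fold higher number from compound 1 to compound 4 (0.23 log units; that floor lies within the scatter), and part of that range lies within the usual scatter. Compound 4 is expected to give about 24 mL.min-1.g-1, with an estimated range from 12 mL.min-1.g-1 to 60 mL.min-1.g-1.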

Compound 4, intrinsic clearance in microsomes: 80 mL.min-1.g-1
Compound 4: the middle estimate sits 3.3-fold (0.52 log units) below what was measured, outside the stated range (above it).
By their numbers in this assay, from the lowest: compounds 2 and 4 (each within the scatter of the next); then compound 3. At a limit, below all of these: compound 1.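

In this assay, putting oxan-4-yl in place of methoxy on this aromatic carbon, next to the ring nitrogen, gives an at least 5.7-fold higher number from compound 1 to compound 4 (0.75 log units; beyond the scatter). This single change therefore moves the number beyond the usual scatter, which compound 2 and compound 3 could not show, since they differ from compound 1 in more than one place. The step has only a lower bound, because compound 1 stands at a limit and not at a number: the limit of < 14 mL.min-1.g-1 in this assay, at which 1 of the 4 values shown sits.

From the compounds shown here alone, it remains open whether the rise comes from the ring itself or simply from a larger group, which an open chain such as 2-methoxyethyl or an amine such as morpholin-4-yl at this place could help to separate. Also open, going by these compounds, is whether the swap would act the same way with the other groups carried by compound 2 and compound 3.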